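The compounds below may be only part of what the source reports. "The series", "measured", "known", "first", "only" and "open" are said of these compounds alone.

Working notes on the cytotoxicity series.

Compound 1 `c1ccc([C@@H]2C[C@@H]3Cc4ccc5ccccc5c4N2O3)cc1` is the parent with an unsubstituted phenyl on the saturated ring carbon. Within the data shown here, in an ADME assay on Vero cells (Chlorocebus sabaeus) for cytotoxicity, read by MTT assay, with a stated time of 72 h (a higher number here means that more compound is tolerated, a lower number that less compound is tolerated), compound 1 gives 72900 nM, which is the highest of the two plain numbers so far; the nearest is compound 3 `Clc1ccccc1[C@@H]1C[C@@H]2Cc3ccc4ccccc4c3N1O2`, which in this assay gives 37200 nM, a gap within the scatter. Compound 2 `Cc1cccc([C@@H]2C[C@@H]3Cc4ccc5ccccc5c4N2O3)c1` reaches only a limit in this assay, where compound 2 gives > 300000 nM (the limit of > 300000 nM in this assay, at which 1 of the 3 values shown sits).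

The step to compound 4 `Clc1ccc([C@@H]2C[C@@H]3Cc4ccc5ccccc5c4N2O3)c(Cl)c1` is 2,4-dichlorophenyl in place of phenyl on a saturated ring carbon.

Among the measured compounds shown here, two measured steps bear on it. The change to compound 3 gives a 2.0-fold lower number from compound 1 to compound 3 (0.29 log units; within the scatter), so a single chloro leaves the number essentially where it was. For the measured compounds named here, the methyl change gives an at least 4.1-fold higher number from compound 1 to compound 2 (0.61 log units; beyond the scatter), in the opposite direction, and compound 2 to compound 3 gives an at least 8.0-fold lower number from compound 2 to compound 3 (0.90 log units; beyond the scatter); but no measured step introduces a second chloro, and the second chloro sits in a place not probed here. The chloro evidence, being within the scatter, suggests no step beyond the scatter in this assay, with a slight lean toward a lower number.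

Compound 4 is therefore expected to give 40000 nM in this assay, with a range of 15000 nM to 120000 nM, which corresponds to an expected step of a 1.8-fold lower number from compound 1 to compound 4 (0.26 log units; within the scatter).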

Compound 4, half-maximal cytotoxic concentration: 55000 nM
The estimate for compound 4 lay 1.4-fold (0.14 log units) below the measured number, and the stated range covers the measured number.
By their numbers in this assay, from the lowest: compounds 3, 4 and 1 (each within the scatter of the next). At a limit, above all of these: compound 2.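

In this assay, the 2,4-dichlorophenyl group on the saturated ring carbon next to the ring nitrogen stays within the scatter of the parent phenyl (a 1.3-fold lower number from compound 1 to compound 4 (0.12 log units; within the scatter)), and the added chloro also stays within the scatter of the single-chloro compound (a 1.5-fold higher number from compound 3 to compound 4 (0.17 log units; within the scatter)), so neither one nor two chloro groups on this phenyl separate compounds 1, 3 and 4 from one another. Against this tight group, the 3-methylphenyl compound remains clearly apart, now from the dichloro compound as well (an at least 5.4-fold lower number from compound 2 to compound 4 (0.73 log units; beyond the scatter)). Compound 2 remains a limit of the assay, so the full size of this gap is not fixed: the limit of > 300000 nM in this assay, at which 1 of the 4 values shown sits.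

Open is whether the separation of compound 2 follows the methyl itself or its place on the phenyl, since the series shown holds a single methyl compound and no chloro group at that same place. Also open, going by these compounds, is how the number responds to a longer chain such as ethyl, or to an amine or a carboxylic acid, on this phenyl.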